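The source may report more compounds than this note shows. Statements on the series, on what has been measured and on what is new or still open speak of the compounds shown alone.

Measured so far:
compound 1 `O=C(CSc1nc(Nc2ccccc2)c2ccccc2n1)Nc1ccc(C(F)(F)F)cc1`, 11100 nM
compound 2 `CCc1ccc(NC(=O)CSc2nc(Nc3ccccc3)c3ccccc3n2)cc1`, 33900 nM
compound 3 `C=CC(=O)Nc1cccc(NC(=O)CSc2nc(Nc3ccc(C(F)(F)F)cc3)c3ccccc3n2)c1`, 11500 nM

All three numbers come from a functional assay on MDA-MB-231 cells (Homo sapiens) for inhibition, read by MTT assay, with a stated time of 72 h; on this read-out lower numbers stand for stronger inhibition and higher numbers for weaker inhibition. Compound 1 and compound 2 share one core and differ only by ethyl in place of trifluoromethyl on an aromatic carbon; that single change gave a 3.1-fold higher number from compound 1 to compound 2 (0.48 log units; beyond the scatter). Compound 3 rests on a different core, and the difference between the two cores is not broken down here. In this assay compound 3 and compound 1 give numbers within the usual scatter of each other, while compound 2 gives the higher number of the three.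

Compound 4 `C=CC(=O)Nc1cccc(NC(=O)CSc2nc(Nc3ccc(CC)cc3)c3ccccc3n2)c1` has not yet been measured in this assay. Among the measured compounds shown here, it differs from compound 3 by ethyl in place of trifluoromethyl on an aromatic carbon, which is the same change, at the same kind of place, as the one separating compound 1 and compound 2. For the measured compounds named here, only one precedent exists for it, so the expectation rests on that step alone. The expected step is a 3.0-fold higher number from compound 3 to compound 4 (0.47 log units; beyond the scatter), because the same change earlier gave a 3.1-fold higher number from compound 1 to compound 2 (0.48 log units; beyond the scatter). Compound 4 is therefore expected to give about 34000 nM, with a plausible range from 12000 nM to 95000 nM.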

Compound 4, half-maximal inhibitory concentration: 14400 nM
Compound 4: the middle estimate sits 2.4-fold (0.37 log units) above what was measured, and the stated range covers the measured number.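

In this assay ethyl in place of trifluoromethyl on an aromatic carbon gives a 1.3-fold higher number from compound 3 to compound 4 (0.10 log units; within the scatter) on one core, and the same change gave a 3.1-fold higher number from compound 1 to compound 2 (0.48 log units; beyond the scatter) on the other.
Set side by side, the two steps cannot be told apart: the same change on two cores in this assay, a 3.1-fold higher number (0.48 log units; beyond the scatter) from compound 1 to compound 2 and a 1.3-fold higher number (0.10 log units; within the scatter) from compound 3 to compound 4, 2.4-fold (0.39 log units) apart, within the scatter of two such steps
The result is therefore compatible with the change carrying over from one core to the other, but with one step beyond the scatter and the other within it, a single pair on each core does not show that the change has the same size on both, nor that it moves the number at all on the newer core.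

On these data alone, whether an amine, a carboxylic acid or a longer chain in place of ethyl would shift the number on either core remains open. Also open, as far as these compounds go, is whether the pattern seen in these two pairs holds on any further core.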